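Ester homologation on the side-chain acyl group of compound 1

The source may hold more compounds than are shown below. What is called first, only, known or untested is meant among the compounds shown, and "the series" means these compounds.

Measured so far:
compound 1, `CCOC(=O)C1=C(S[C@@H]2CN[C@H](C(=O)Nc3cccc(C(=O)OCC)c3)C2)[C@H](C)[C@@H]2[C@@H]([C@@H](C)OC(C)=O)C(=O)N12`: 23.3%
compound 2, `CCOC(=O)C1=C(S[C@H]2C[C@@H](C(=O)Nc3cccc(C(=O)OCC)c3)N(C(=O)OCc3oc(=O)oc3C)C2)[C@H](C)[C@@H]2[C@@H]([C@@H](C)O)C(=O)N12`: 14.4%

Both were run in an ADME assay on the whole organism (strain Beagle) for pharmacokinetics, with Canis familiaris (Canis lupus familiaris) as the target, read by LC-MS, at a dose of 10 mg/kg; on this read-out higher numbers stand for higher oral bioavailability and lower numbers for lower oral bioavailability. Compound 1 gives 23.3% and compound 2 gives 14.4%; the two values lie within the usual scatter of each other, so nothing separates them. Among the measured compounds shown here, no step between one-place neighbours exists in this set.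

Compound 3, `CCOC(=O)C1=C(S[C@@H]2CN[C@H](C(=O)Nc3cccc(C(=O)OCC)c3)C2)[C@H](C)[C@@H]2[C@@H]([C@@H](C)OC(=O)CC)C(=O)N12`, differs from compound 1 by methyl in place of hydrogen on a saturated chain carbon bound to a carbonyl carbon, the acetyl becoming propanoyl. For the measured compounds named here, with no comparable step among the measured pairs, the change is expected to give none beyond the scatter, estimated as a number 0.3 percentage points lower from compound 1 to compound 3 (within the scatter). For compound 3 the expected value is 23%, in the range 10% to 38%.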

Compound 3, oral bioavailability: 20.2%
Beside the measured number, compound 3's estimate is 2.8 percentage points above it; the range from low to high includes it.
By their numbers in this assay, from the lowest: compounds 2, 3 and 1 (each within the scatter of the next).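

In this assay, among the compounds shown here, acetyl to propanoyl gives a number 3.1 percentage points lower from compound 1 to compound 3 (within the scatter), the first step between compounds that differ in one place. On the evidence of this one pair, methyl in place of hydrogen on a saturated chain carbon bound to a carbonyl carbon is tolerated, with no change that can be told from the scatter. No measurement here bears on what lies behind this result.

Open, going by these compounds, is whether a longer chain on the acyl group, such as butanoyl or hexanoyl, would also stay within the scatter of compound 1. The same holds for an amine carried on that chain.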